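A Pyridine Swap at the Edge of the Assay

The compounds below may be only part of what the source reports. "The series", "measured", "known", "first", "only" and "open" are said of these compounds alone.

Compound 1 `C[C@H](Nc1ncnc2[nH]cnc12)c1nn(-c2cccnc2)c2ccc(F)cc12` gives 31900 nM
Compound 2 `C[C@H](Nc1ncnc2[nH]cnc12)c1nn(-c2cccnc2)c2cc(Cl)ccc12` gives > 40000 nM (a limit)
Compound 3 `C[C@H](Nc1ncnc2[nH]cnc12)c1nn(-c2cccc(F)c2)c2cc(F)ccc12` gives > 40000 nM (a limit)

All three compounds were read in a functional assay on Bel-7402 cells (Homo sapiens) for inhibition, read by sulforhodamine B assay, with a stated time of 72 h (on this read-out higher numbers stand for weaker inhibition and lower numbers for stronger inhibition), where compound 4 `C[C@H](Nc1ncnc2[nH]cnc12)c1nn(-c2cccnc2)c2cc(F)ccc12` has yet to be measured. For compound 3 the result is only a limit, > 40000 nM, and so it has no number of its own. That is the limit of > 40000 nM in this assay, at which 2 of the 3 values shown sit, in the series.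

The step to compound 4 puts pyridin-3-yl in place of 3-fluorophenyl on an aromatic nitrogen. Among the compounds with values here, no measured step shows what this exchange does. Within the data shown here, compound 1 also carries pyridin-3-yl and gives 31900 nM, the only true number so far. Compound 2 carries pyridin-3-yl too, yet its result is again a limit, > 40000 nM. On this evidence, no change beyond the usual scatter is expected, and compound 4 may well return a limit as well. The expected step is an at least 1.1-fold lower number from compound 3 to compound 4 (0.05 log units; that floor lies within the scatter) in this assay. For compound 4 the estimated value is 35000 nM, with an expected range from 15000 nM to 70000 nM.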

Compound 4, half-maximal inhibitory concentration: > 40000 nM
Compound 4: no number, only a limit; the forecaster's own chance of this, stated with the estimate: 55%; at least 1.1-fold (0.05 log units) between middle value and limit.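

In this assay compound 4 gives > 40000 nM, which is a limit and not a number. Its steps from compound 3 and from compound 2 cannot be read, because all three compounds sit at the same limit: the limit of > 40000 nM in this assay, at which 3 of the 4 values shown sit.

Going by these compounds, what pyridin-3-yl in place of 3-fluorophenyl, or fluoro in place of chloro, does to inhibition stays open.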